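Methylating a phenol on a pyrazole urea series

A few compounds are considered here, and "the series" means these few. Any claim that something is new, unique, unknown or untested is made for them only; others in the source may bear on it.

Compound 3 `O=C(Nc1cccc(-n2cc(-c3ccncc3)c(-c3cc(O)cc(Cl)c3)n2)c1)Nc1ccc(Cl)c(Cl)c1` stands lowest of the three compounds measured in a functional assay on SF-295 cells (Homo sapiens) for inhibition, read by sulforhodamine B assay, with a stated time of 48 h, tested at 10 uM; on this read-out higher numbers stand for a weaker effect at the one concentration tested and lower numbers for a stronger effect: compound 3 gives -50.5%. Its nearest neighbour on the numbers is compound 1 `COc1cc(Cl)cc(-c2nn(-c3cccc(NC(=O)Nc4cccc(C(F)(F)F)c4)c3)cc2-c2ccncc2)c1`, which in this assay gives -7.87%, and the furthest is compound 2 `COc1cc(Cl)cc(-c2nn(-c3cccc(NC(=O)c4cccc(C(F)(F)F)c4)c3)cc2-c2ccncc2)c1`, which in this assay gives 37.9%. Among the measured compounds shown here, the only step that can be followed between two measured compounds is a number 45.8 percentage points higher from compound 1 to compound 2 (beyond the scatter); it concerns the carbonyl side of the molecule and so says nothing directly about the change now at hand.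

Compound 4 `COc1cc(Cl)cc(-c2nn(-c3cccc(NC(=O)Nc4ccc(Cl)c(Cl)c4)c3)cc2-c2ccncc2)c1` is compound 3 with a single alteration: methyl in place of hydrogen on an oxygen on an aromatic ring. For the measured compounds named here, no measured pair isolates this hydroxy to methoxy exchange. Compounds 1 and 3 differ both here and in the aryl group on the urea, so their two values cannot be apportioned to either change. In the absence of a bearing step, the exchange of a hydrogen for a methyl on an oxygen is expected to leave the result close to that of compound 3, with the step of a number 15.5 percentage points higher from compound 3 to compound 4 (beyond the scatter) expected to fall within or only modestly beyond the scatter. Compound 4 is therefore estimated at -35%, within a range from -70% to 5%.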

Compound 4, a percentage reported as activity, at one concentration (the size of the read-out at that concentration, not a potency): -2.42%
Estimate against measurement, compound 4: 32.6 percentage points below; the range from low to high includes it.
By their numbers in this assay, from the lowest: compound 3; then compounds 1 and 4 (each within the scatter of the next); then compound 2.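

The hydroxy to methoxy exchange on the aromatic ring now stands alone in this assay: the step is a number 48.1 percentage points higher from compound 3 to compound 4 (beyond the scatter) and shows that, with the 3,4-dichlorophenyl urea held fixed, this one oxygen substituent changes the read-out substantially, with the lower number belonging to the free hydroxy. With methoxy in place on both compounds, the aryl group on the urea shows no separable effect, as the step is a number 5.5 percentage points higher from compound 1 to compound 4 (within the scatter). The gap between the values of compounds 1 and 3 therefore tracks the oxygen change more closely than the aryl change. The carbonyl side keeps its weight on the methoxy series, since the step is a number 40.3 percentage points lower from compound 2 to compound 4 (beyond the scatter). This matches the direction of the earlier step between compounds 1 and 2, while no available evidence explains either change.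

On these data alone, it remains open whether the hydroxy would give a similar step on the 3-(trifluoromethyl)phenyl urea or on the amide of compound 2. Also open, as far as these compounds go, is how this oxygen would behave carrying an ethyl group, a longer chain ending in an amine, or a carboxylic acid in place of hydrogen or methyl.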